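Swapping the Aryl Amide for a Cinnamamide

The source may report more compounds than this note shows. Statements on the series, on what has been measured and on what is new or still open speak of the compounds shown alone.

Of the compounds shown here, three sharing one core have been measured so far in a functional assay on MDA-MB-468 cells (Homo sapiens) for antiproliferative activity, read by MTT assay, with a stated time of 48 h; a higher number here means a weaker inhibitor, a lower number a stronger inhibitor. Compound 1 `COc1cccc(C(=O)Nc2cc3cnc(NCCN(C)C)cc3n(C)c2=O)c1` gives 17400 nM, the highest of the three numbers. For the measured compounds named here, compound 3 `COc1ccc(C(=O)Nc2cc3cnc(N4CCN(C)CC4)cc3n(C)c2=O)cc1` gives 12600 nM, a number that lies within the usual scatter of the one for compound 1, so no order between them can be read. Going by the values given here, compound 2 `CN(C)CCNc1cc2c(cn1)cc(NC(=O)c1ccncc1)c(=O)n2C` gives 8360 nM; the change a 2.1-fold lower number from compound 1 to compound 2 (0.32 log units; beyond the scatter) is a modest step beyond the scatter, and it is the only measured step that alters the group on the carbonyl carbon.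

Compound 4 `CN(C)CCNc1cc2c(cn1)cc(NC(=O)/C=C/c1ccccc1)c(=O)n2C` has not yet been measured. It differs from compound 1 in one place: 2-phenylethenyl in place of 3-methoxyphenyl on a carbonyl carbon. Among the compounds with values here, the single step from compound 1 to compound 2 shows that replacing the group on this carbonyl carbon can shift the number by a modest amount, though in that case the entering group was a different one. Within the data shown here, with only one such step to lean on, the expected change is small and its direction uncertain. Compound 4 is therefore estimated to give about 12000 nM, with a plausible range from 4000 nM to 40000 nM, which corresponds to an expected step of a 1.5-fold lower number from compound 1 to compound 4 (0.16 log units; within the scatter).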

Compound 4, half-maximal inhibitory concentration: 12100 nM
The estimate for compound 4 lay 1.0-fold (0.00 log units) below the measured number, and the stated range covers the measured number.
By their numbers in this assay, from the lowest: compounds 2, 4, 3 and 1 (each within the scatter of the next, the first and the last beyond it).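

In this assay, replacing 3-methoxyphenyl on the carbonyl carbon with 2-phenylethenyl gives a 1.4-fold lower number from compound 1 to compound 4 (0.16 log units; within the scatter) as the step, so removing the ring's oxygen-bearing substituent and placing a double bond outside the ring produces no readable change, even though both groups have the same heavy-atom count. The step to the pyridin-4-yl compound gives a 1.4-fold higher number from compound 2 to compound 4 (0.16 log units; within the scatter) and also stays within the scatter, so compound 4 cannot be grouped with either compound 1 or compound 2, although those two are separated by a step beyond the scatter. No accompanying measurement offers an explanation for these numbers.

Still open, as far as these compounds go, is whether the double bond itself matters, a question that a saturated 2-phenylethyl group on the same carbonyl carbon would address directly. It is equally unknown whether an amine or a carboxylic acid on the ring of the 2-phenylethenyl group would move the number beyond the scatter, or whether a simple methyl group in place of the whole aryl portion would do so.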